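A Sulfur Group in Place of Methoxy

The source may report more compounds than this note shows. Statements on the series, on what has been measured and on what is new or still open speak of the compounds shown alone.

In a functional assay for inhibition, with Homo sapiens as the target (a higher number here means a weaker inhibitor, a lower number a stronger inhibitor), compound 1 `COc1ccc(-c2nc(-c3ccc4c(c3)CCC(=O)N4)cs2)cc1OC` gives 300 nM, level with compound 3 `CCCCOc1cc(-c2nc(-c3ccc4c(c3)CCC(=O)N4)cs2)ccc1OC` at 300 nM, while compound 2 `CCCOc1cc(-c2nc(-c3ccc4c(c3)CCC(=O)N4)cs2)ccc1OC` gives a lower 90 nM. Compound 4 `COc1cc(-c2nc(-c3ccc4c(c3)CCC(=O)N4)cs2)ccc1[S+](C)[O-]` carries a different change: a group of 3 heavy atoms (1 carbon, 1 oxygen, 1 sulfur; no ring) in place of a group of 2 heavy atoms (1 carbon, 1 oxygen; no ring), on an aromatic carbon, ortho to a methoxy group and para to a large group. Going by the values given here, no measured step makes this exchange. The three available steps alter a chain on an oxygen instead: a 3.3-fold lower number from compound 1 to compound 2 (0.52 log units; beyond the scatter), no change at the digits printed from compound 1 to compound 3 (within the scatter) and a 3.3-fold higher number from compound 2 to compound 3 (0.52 log units; beyond the scatter). They offer only a rough guide to size, so a modest rise in the number is expected, with its direction uncertain. The expected step is a 2.0-fold higher number from compound 1 to compound 4 (0.30 log units; within the scatter). Compound 4 is estimated at 600 nM, with an expected range of 150 nM to 2500 nM.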

Compound 4, half-maximal inhibitory concentration: 800 nM
Compound 4: the middle estimate sits 1.3-fold (0.12 log units) below what was measured; low and high end bracket the measured number.
By their numbers in this assay, from the lowest: compound 2; then compounds 1 and 3 (each within the scatter of the next); then compound 4.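

In this assay, replacing the methoxy itself with the group of 3 heavy atoms (1 carbon, 1 oxygen, 1 sulfur) gives a 2.7-fold higher number from compound 1 to compound 4 (0.43 log units; beyond the scatter). Thus, the methoxy on this aromatic carbon, para to a large group, can be exchanged with a measurable loss, whereas earlier steps only altered chains on an oxygen. Nothing available accounts for this rise. The compounds shown leave open how an amine, a carboxylic acid or a methylsulfonyl group would fare on this same carbon.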